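Working notes: amine tail replacements and cell cytotoxicity

This account rests on a few compounds, and the source may have more. Where it says the series, first, only, none or still open, it means among the compounds named here.

Compound 1 `Cc1ccccc1-c1nn(-c2ccc(F)cc2F)cc1CNCCN1CCN(C)CC1`. In an ADME assay on Huh-7 cells (Homo sapiens) for cytotoxicity (on this read-out higher numbers stand for lower toxicity in this test and lower numbers for higher toxicity in this test), compound 1 gives > 20000 nM, which is a limit of the assay.
Compound 2 `CCCN1CCC(CNCc2cn(-c3ccc(F)cc3F)nc2-c2ccccc2C)CC1`. In this assay compound 2 gives > 20000 nM, a limit of the assay.
Compound 3 `Cc1ccccc1-c1nn(-c2ccc(F)cc2F)cc1CNCCN(C)C`. In this assay compound 3 gives > 20000 nM, a limit of the assay.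

Compound 3 therefore stands only as a limit, and the two other values shown are limits as well: the limit of > 20000 nM in this assay, at which 3 of the 3 values shown sit. The three steps among the measured compounds, a step that the two limits leave unreadable from compound 1 to compound 2, a step that the two limits leave unreadable from compound 1 to compound 3 and a step that the two limits leave unreadable from compound 2 to compound 3, cannot be sized, so no direction can be read from them.

Compound 4 `Cc1ccccc1-c1nn(-c2ccc(F)cc2F)cc1CNCc1ccncc1` differs from compound 3 by pyridin-4-yl in place of (dimethylamino)methyl on a saturated chain carbon bound to an amine nitrogen. The measured steps bear on this change only in that every variation of the tail tried so far has remained at the limit in this assay. The step that the limit leaves unreadable from compound 3 to compound 4 is accordingly expected to stay within the scatter. Compound 4 is estimated at 30000 nM, within 15000 nM to 80000 nM, and most likely the assay will again report only a limit for compound 4.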

Compound 4, half-maximal cytotoxic concentration: > 20000 nM
Compound 4: no number, only a limit; the forecaster's own chance of this, stated with the estimate: 85%; the middle value lies beyond the limit too.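

Compound 4 also gives only a limit in this assay, so its steps to compound 1, compound 2 and compound 3 cannot be read: the limit of > 20000 nM in this assay, at which 4 of the 4 values shown sit.

The compounds shown leave open how these amine tails differ in this assay, and whether any tail gives a measurable value.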